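Five-Membered Ring in Place of Six-Membered Ring

The source may report more compounds than this note shows. Statements on the series, on what has been measured and on what is new or still open speak of the compounds shown alone.

Compound 1 `Cc1ccc(NC(=O)c2cccc(C(F)(F)F)c2)cc1OC1CCN(C(=O)c2cccnc2)CC1`: > 10000 nM
Compound 2 `Cc1ccc(NC(=O)c2cccc(C(F)(F)F)c2)cc1OC1CCN(C(=O)c2ccno2)CC1`: > 10000 nM
Compound 3 `Cc1ccc(NC(=O)c2ccc(C)c(C(F)(F)F)c2)cc1OC1CCN(C(=O)c2cccnc2)CC1`: 5470 nM

Of the compounds shown here, three have been tested in an ADME assay on BaF3 cells (Mus musculus) for antiproliferative activity; a higher number here means a weaker inhibitor of growth, a lower number a stronger inhibitor of growth. Compound 1 reaches only a limit of the assay, > 10000 nM. Compound 2 likewise gives a limit, > 10000 nM. Compound 3 alone returns a number, 5470 nM, and so it is the only point on the scale among the three. Within the data shown here, the one step that can be read among them is an at least 1.8-fold lower number from compound 1 to compound 3 (0.26 log units; that floor lies within the scatter).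

Compound 4 `Cc1ccc(NC(=O)c2ccc(C)c(C(F)(F)F)c2)cc1OC1CCN(C(=O)c2ccno2)CC1` has not been measured. It differs from compound 3 in one place: 1,2-oxazol-5-yl in place of pyridin-3-yl on a carbonyl carbon. The same exchange was made once before, from compound 1 to compound 2, where the step is a step that the two limits leave unreadable from compound 1 to compound 2 because both values sit at the limit of > 10000 nM in this assay, at which 2 of the 3 values shown sit. Among the measured compounds shown here, that earlier pair therefore sets no size and no direction for the step now in question. Compound 3 is itself a weak inhibitor of growth, so a change of unknown effect starting there may carry the result to a limit. Compound 4 is expected to give about 7000 nM in this assay, with a range from 2500 nM to 20000 nM, and a considerable chance that only a limit is recorded. The step from compound 3 to compound 4 is estimated as a 1.3-fold higher number from compound 3 to compound 4 (0.11 log units; within the scatter), within the scatter.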

Compound 4, concentration for 50% growth inhibition: 8940 nM
For compound 4 the middle estimate is 1.3-fold (0.11 log units) below the measured one; the measured number falls inside the stated range.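

On the core that carries the extra methyl, the exchange that could not be read on the core of compound 1 now has a size: a 1.6-fold higher number from compound 3 to compound 4 (0.21 log units; within the scatter) in this assay. On this core, then, the 1,2-oxazol-5-yl group on the carbonyl carbon cannot be told apart from pyridin-3-yl, even though a five-membered aromatic ring with 2 hetero atoms has replaced a six-membered one with 1. The methyl on an aromatic carbon can now also be followed on a second core, but its effect there is only a floor, an at least 1.1-fold lower number from compound 2 to compound 4 (0.04 log units; that floor lies within the scatter), and the two cores together give no firm comparison: the same change on two cores in this assay, an at least 1.8-fold lower number (0.26 log units; that floor lies within the scatter) from compound 1 to compound 3 and an at least 1.1-fold lower number (0.04 log units; that floor lies within the scatter) from compound 2 to compound 4; the limit leaves it open whether they differ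

As far as these compounds go, whether any group on that carbonyl carbon can move the number beyond the scatter stays open, for instance a pyridine ring carrying an amine or a phenyl ring carrying a carboxylic acid. It is also unknown how large the methyl step really is on either core, and whether an ethyl or a chlorine on that aromatic carbon would give a step that can be read beyond the scatter.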